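This account rests on a few compounds, and the source may have more. Where it says the series, first, only, none or still open, it means among the compounds named here.

Among the measured compounds shown here, compound 2 `CCc1nn(C)c2c1C(c1ccccc1)=NCC(=O)N2` holds the only number here: in a functional assay on the whole organism (strain Holtzman) with Rattus norvegicus as the target (a lower number here means that less compound is needed, a higher number that more compound is needed for the effect), compound 2 gives 2.5 mg/kg. Compound 1 `Cn1ncc2c1NC(=O)CN=C2c1ccccc1` sits at a limit of the assay, > 80 mg/kg; that is the limit of > 80 mg/kg in this assay, at which 1 of the 2 values shown sits. For the measured compounds named here, the one measured step, an at least 32-fold lower number from compound 1 to compound 2 (1.50 log units; beyond the scatter), came from ethyl in place of hydrogen on an aromatic carbon. Compound 3 `Cn1nc(Cl)c2c1NC(=O)CN=C2c1ccccc1` differs from compound 2 by chloro in place of ethyl on an aromatic carbon, on that same aromatic carbon. Going by the values given here, since the only step at this aromatic carbon was an at least 32-fold lower number from compound 1 to compound 2 (1.50 log units; beyond the scatter), a change there is expected to matter, here toward a higher number, a 4.0-fold higher number from compound 2 to compound 3 (0.60 log units; beyond the scatter). Compound 3 is estimated at 10 mg/kg, within 3 mg/kg to 40 mg/kg.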

Compound 3, minimum effective dose: 40 mg/kg
Estimate against measurement, compound 3: 4.0-fold (0.60 log units) below; low and high end bracket the measured number.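

At this aromatic carbon, the choice of group matters and not only whether a group is present: chloro in place of ethyl gives a 16-fold higher number from compound 2 to compound 3 (1.20 log units; beyond the scatter). Chloro in place of hydrogen gives an at least 2.0-fold lower number from compound 1 to compound 3 (0.30 log units; that floor lies within the scatter), so of the two groups shown, only ethyl has a step from hydrogen that clearly lies beyond the scatter. Compound 1 stands at a limit, so its steps have only a floor: the limit of > 80 mg/kg in this assay, at which 1 of the 3 values shown sits.

Going by these compounds, whether a longer chain such as propyl would match ethyl here remains open. So does what an amine on this carbon would do.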